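Chloro removal on the shared core of compound 2

The source may hold more compounds than are shown below. What is called first, only, known or untested is meant among the compounds shown, and "the series" means these compounds.

Compound 2 `Cc1cc(N2CCN(C(=O)Nc3ccc(OC(F)(F)F)cc3)CC2)nnc1Cl` is assessed in an assay on HEK293 cells for inhibition of transient receptor potential cation channel subfamily V member 1 (Homo sapiens), read by FLIPR; on this read-out lower numbers stand for stronger inhibition and higher numbers for weaker inhibition. In this assay compound 2 gives > 10000 nM, which is a limit of the assay and not a number. Compound 1 `Cc1cc(N2CCN(C(=O)Nc3ccc(C(C)C)cc3)CC2)nnc1Cl` carries the same shared core; in this assay compound 1 gives > 10000 nM, likewise a limit. The change from compound 1 to compound 2 is a step that the two limits leave unreadable from compound 1 to compound 2, and the two limits leave its size unreadable, as the limit of > 10000 nM in this assay, at which 2 of the 2 values shown sit, shows. Compound 3 `Cc1cnnc(N2CCN(C(=O)Nc3ccc(OC(F)(F)F)cc3)CC2)c1` is not yet measured. It differs from compound 2 by hydrogen in place of chloro on an aromatic carbon, or, cut one bond further out, 6-chloro-5-methylpyridazin-3-yl to 5-methylpyridazin-3-yl. No measured step touches this part of the shared core; the only step shown exchanges isopropyl for trifluoromethoxy and is itself unreadable. Nothing in the numbers therefore points to a change in this assay beyond the scatter, and the expectation is that compound 3 remains at the limit. For compound 3 the estimate in this assay is 20000 nM, within 5000 nM to 80000 nM. The step that this estimate means is a step that the limit leaves unreadable from compound 2 to compound 3, expected to stay within the scatter.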

Compound 3, half-maximal inhibitory concentration: > 10000 nM
Compound 3 gave a limit, no number; the forecaster's own chance of this, stated with the estimate: 85%; the middle value is on the limit's open side.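

The step from compound 2 to compound 3 cannot be read, and neither limit gives it a size: the limit of > 10000 nM in this assay, at which 3 of the 3 values shown sit.

On these data alone, with no numerical value among compound 1, compound 2 and compound 3, it stays open what chloro, isopropyl or trifluoromethoxy contributes to inhibition, and which change on the shared core would give a measurable value.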